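Adding chloro to the phenyl of compound 2

A few compounds are considered here, and "the series" means these few. Any claim that something is new, unique, unknown or untested is made for them only; others in the source may bear on it.

- compound 1 `COC(=O)C(C)Nc1cc(NS(=O)(=O)/C=C/c2c(OC)cc(OC)cc2OC)ccc1OC`: 100 nM
- compound 2 `COC(=O)C(Nc1cc(NS(=O)(=O)/C=C/c2c(OC)cc(OC)cc2OC)ccc1OC)c1ccccc1`: 2500 nM

In a functional assay on DU-145 cells (Homo sapiens) for cytotoxicity, read by trypan blue exclusion, with a stated time of 96 h (a higher number here means a weaker inhibitor, a lower number a stronger inhibitor), compound 2 has the higher of the two numbers, the weaker result, at 2500 nM. Compound 3 `COC(=O)C(Nc1cc(NS(=O)(=O)/C=C/c2c(OC)cc(OC)cc2OC)ccc1OC)c1ccc(Cl)cc1` differs from it by chloro in place of hydrogen on an aromatic carbon. Going by the values given here, the only measured step, a 25-fold higher number from compound 1 to compound 2 (1.40 log units; beyond the scatter), was large, but it put phenyl in place of methyl and says nothing about chloro on that phenyl. No step beyond the scatter is therefore expected, though with wide uncertainty. The estimated change is a 1.3-fold lower number from compound 2 to compound 3 (0.10 log units; within the scatter). The expected value for compound 3 is 2000 nM, within an estimated range of 500 nM to 8000 nM.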

Compound 3, half-maximal inhibitory concentration: 5000 nM
The estimate for compound 3 lay 2.5-fold (0.40 log units) below the measured number, and the stated range covers the measured number.
By their numbers in this assay, from the lowest: compound 1; then compounds 2 and 3 (each within the scatter of the next).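

In this assay, chloro on the phenyl ring, para to a large group, gives a 2.0-fold higher number from compound 2 to compound 3 (0.30 log units; within the scatter), so this change does not separate compound 3 from compound 2. The large step away from methyl remains with the chlorine in place, as 4-chlorophenyl in place of methyl gives a 50-fold higher number from compound 1 to compound 3 (1.70 log units; beyond the scatter). No available evidence explains either result. Still open, from the compounds shown here alone, is how an amine on the phenyl ring would read here, and whether an ethyl group or a longer chain in place of methyl would keep the number of compound 1.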